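Losing the amine hydrogen at a weakly active cyclopentyl position

A few compounds are considered here, and "the series" means these few. Any claim that something is new, unique, unknown or untested is made for them only; others in the source may bear on it.

The series shares one core and varies the amine on a double-bonded ring carbon. Compound 1 `CCCc1ccc(NC2=CC(=O)c3nc4n(c3C2=O)[C@H]2OC[C@@H](O)[C@H]2OC4)cc1` carries a 4-propylphenyl amine and in a functional assay on MGC-803 cells (Homo sapiens) for inhibition, read by sulforhodamine B assay (a lower number here means a stronger inhibitor, a higher number a weaker inhibitor), compound 1 gives 1560 nM. Compound 2 `O=C1C(Nc2ccc(Br)cc2)=CC(=O)c2c1nc1n2[C@H]2OC[C@@H](O)[C@H]2OC1` carries a 4-bromophenyl amine and in this assay compound 2 gives 2020 nM; the two values lie within the scatter of each other. Compound 3 `O=C1C=C(NC2CCCC2)C(=O)c2c1nc1n2[C@H]2OC[C@@H](O)[C@H]2OC1` carries a cyclopentyl amine instead. In this assay compound 3 reaches only the limit of the assay, > 8000 nM, so its place is a range rather than a number. For the measured compounds named here, the one step into compound 3 was an at least 5.1-fold higher number from compound 1 to compound 3 (0.70 log units; beyond the scatter), the swap of the aryl amine for a cycloalkyl amine.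

Compound 4 `O=C1C=C(N2CCCC2)C(=O)c2c1nc1n2[C@H]2OC[C@@H](O)[C@H]2OC1` differs from compound 3 in one place: pyrrolidin-1-yl in place of cyclopentylamino on a double-bonded ring carbon. Going by the values given here, no measured step tracks this change; the only step touching compound 3 moved it to the limit (the limit of > 8000 nM in this assay, at which 1 of the 3 values shown sits), so compound 4 starts from a range, not a value. The account therefore expects compound 4 to stay in that weak region, with a step that the limit leaves unreadable from compound 3 to compound 4 estimated as no shift beyond the scatter, and it is estimated that compound 4 gives 10000 nM in this assay, ranging from 3000 nM to 30000 nM.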

Compound 4, half-maximal inhibitory concentration: > 16000 nM
Compound 4 gave a limit, no number; the forecaster's own chance of this, stated with the estimate: 65%; middle value at least 1.6-fold (0.20 log units) away from the limit.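

In this assay, for the compounds shown here, compound 3 and compound 4 both stand at limits of the assay rather than at numbers, and no step between them can be read. The compounds shown leave open whether pyrrolidin-1-yl in place of cyclopentylamino, which removes the amine hydrogen, shifts the result in this assay at all, and in which direction.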